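The source may hold more compounds than are shown below. What is called first, only, known or untested is meant among the compounds shown, and "the series" means these compounds.

Working notes on the series.

Two cores are in play. Compound 1 `O=C(CCCCC1CCSS1)Nc1ccccn1` and compound 2 `O=C(CCCCC1CCSS1)Nc1ccc(Cl)cn1` share one; compound 3 `O=C(CCCCC(CCSC(=O)c1ccccc1)SC(=O)c1ccccc1)Nc1ccccc1` and compound 4 `O=C(CCCCC(CCSC(=O)c1ccccc1)SC(=O)c1ccccc1)Nc1ccccc1Cl` share the other. The difference between the two cores is not broken down here.

In a functional assay on KB cells (Homo sapiens) for inhibition, read by MTT assay, with a stated time of 24 h, tested at 100 ug/mL (on this read-out lower numbers stand for less inhibition of growth and higher numbers for more inhibition of growth at the one concentration tested), compound 1 gives 25.1%. In this assay compound 2 gives 74.5%. The step of a number 49.4 percentage points higher from compound 1 to compound 2 (beyond the scatter) goes with chloro in place of hydrogen on an aromatic carbon. In this assay compound 3 is reported as "not active" (no number reported), with no number attached, so no single value stands for it.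

Compound 4 is not yet measured. It carries chloro in place of hydrogen on an aromatic carbon. Within the data shown here, this is the same kind of change as the one from compound 1 to compound 2, not the same change: in compound 2 the chloro sits on a six-membered aromatic ring with one nitrogen, two atoms from the ring nitrogen and para to a large group, whereas in compound 4 it sits on a six-membered aromatic ring of carbon only, ortho to a large group. The change has been seen measured only once among these compounds.

Compound 4 is expected to lie clearly above where compound 3 stands, because a number 49.4 percentage points higher from compound 1 to compound 2 (beyond the scatter) is a large rise, but with wide uncertainty since the core and the surroundings of the place differ and compound 3 has no number. Compound 4 is estimated at about 30% in this assay, between 0% and 65%.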

Compound 4, percent growth inhibition at one concentration: "not active" (no number reported)
For compound 4 the study gives words and no number, so the estimate cannot be set against anything.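

In this assay compound 3 and compound 4 are both reported in words without a number, so no step can be read between them. The compounds shown leave open what chloro in place of hydrogen does on this core, and whether a number 49.4 percentage points higher from compound 1 to compound 2 (beyond the scatter) has any counterpart there. No measured evidence bears on this result.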